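The compounds below may be only part of what the source reports. "The series", "measured", "known", "first", "only" and "open" are said of these compounds alone.

The study measures three compounds in an ADME assay on MRC5 cells (Homo sapiens) for inhibition, with a stated time of 72 h; a lower number here means that less compound is needed, a higher number that more compound is needed for the effect. Compound 1 `CO[C@H]1CC[C@H](NC(=O)c2n[nH]cc2NC(=O)c2ncoc2-c2ccccc2)CC1` gives 28000 nM there, and compound 3 `CO[C@H]1CC[C@H](NC(=O)c2n[nH]cc2NC(=O)c2cc3ccccn3n2)CC1` gives 1000 nM in this assay. Compound 2 `COc1cccc(OC)c1C(=O)Nc1c[nH]nc1C(=O)NC1CC1` stands apart: in this assay compound 2 returns only a limit, > 50000 nM, and not a number. That limit is where one of the three values shown sits (the limit of > 50000 nM in this assay, at which 1 of the 3 values shown sits). Compound 4 `COc1cccc(OC)c1C(=O)Nc1c[nH]nc1C(=O)NC1CCC1` is not yet measured; it differs from compound 2 by cyclobutyl in place of cyclopropyl on an amide-type nitrogen. Among the compounds with values here, no measured pair in this set differs in only this place. The expected step is none beyond the usual scatter, a step that the limit leaves unreadable from compound 2 to compound 4. Compound 4 is therefore expected to give about 60000 nM in this assay, within a range from 20000 nM to 200000 nM, most likely again as a limit rather than a number.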

Compound 4, half-maximal effective concentration: > 50000 nM
Compound 4 ended at the assay's limit; the forecaster's own chance of this, stated with the estimate: 75%; the middle value is on the limit's open side.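

Within the data shown here, compound 2 and compound 4 both return only a limit in this assay, and no step between them can be read. The compounds shown leave open how cyclobutyl and cyclopropyl on an amide-type nitrogen compare in this assay.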